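This account rests on a few compounds, and the source may have more. Where it says the series, first, only, none or still open, it means among the compounds named here.

In an ADME assay on K562 cells (Homo sapiens) for cytotoxicity, with a stated time of 72 h (a higher number here means a weaker inhibitor, a lower number a stronger inhibitor), three compounds that share one core differ only in the aromatic group on the chain carbon: compound 1 `Oc1cccc(CNc2ncnc3c2ncn3C2CCCO2)c1` has 3-hydroxyphenyl, compound 2 `COc1ccccc1CNc1ncnc2c1ncn2C1CCCO1` has 2-methoxyphenyl and compound 3 `COc1ccc(CNc2ncnc3c2ncn3C2CCCO2)cc1` has 4-methoxyphenyl. Compound 1 gives > 100000 nM, which is a limit and not a number. Compound 2 gives > 100000 nM, also a limit. Compound 3 gives > 100000 nM, again a limit. Compound 2 therefore has no exact value, and the whole series sits at one reading: the limit of > 100000 nM in this assay, at which 3 of the 3 values shown sit.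

Compound 4 `COc1ccc(OC)c(CNc2ncnc3c2ncn3C2CCCO2)c1` keeps the 2-methoxyphenyl group of compound 2 and gains a second methoxy in place of hydrogen on an aromatic carbon. The measured comparisons are a step that the two limits leave unreadable from compound 1 to compound 2, a step that the two limits leave unreadable from compound 1 to compound 3 and a step that the two limits leave unreadable from compound 2 to compound 3. None of them gives a size, so no step beyond the scatter is expected in this assay. The expected change is a number no higher from compound 2 to compound 4 (the limit leaves the size open). For compound 4 the estimate is 100000 nM, with an expected range from 50000 nM to 200000 nM.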

Compound 4, half-maximal inhibitory concentration: > 50000 nM
Compound 4 ended at the assay's limit; the forecaster's own chance of this, stated with the estimate: 85%; the middle value is on the limit's open side.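

Compound 2 and compound 4 both carry limits and not numbers, so the step between them, methoxy in place of hydrogen on an aromatic carbon, cannot be read. The compounds shown leave open whether these aromatic groups differ at all in this assay.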